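Swapping a furanylmethyl arm for a fluorophenyl ring

The compounds below may be only part of what the source reports. "The series", "measured", "known", "first", "only" and "open" are said of these compounds alone.

In an ADME assay on MDBK cells (Bos taurus) for cytotoxicity, read by MTT assay, with a stated time of 96 h (a lower number here means that less compound is tolerated, a higher number that more compound is tolerated), compound 3, with structure `FC(F)(F)c1cccc(NC(=S)NCc2ccco2)c1`, gives only a limit, > 100000 nM, not a measured number. Compound 1, `Fc1ccccc1NC(=S)Nc1cccc(C(F)(F)F)c1`, sits at the same limit, > 100000 nM. Compound 2, `FC(F)(F)c1cccc(NC(=S)Nc2ccc(I)cc2)c1`, gives 9500 nM in this assay. The unmeasured compound 4, `Fc1cccc(NC(=S)Nc2cccc(C(F)(F)F)c2)c1`, differs from compound 3 by 3-fluorophenyl in place of (furan-2-yl)methyl on an amide-type nitrogen. Among the measured compounds shown here, the only readable step involving this kind of swap is an at least 10-fold higher number from compound 2 to compound 3 (1.02 log units; beyond the scatter), running the opposite way; the other, a step that the two limits leave unreadable from compound 1 to compound 3, cannot be sized because of the limit of > 100000 nM in this assay, at which 2 of the 3 values shown sit. Since compound 1 also carries a fluorophenyl group and stays at the limit, a step in this assay of about an at least 1.2-fold lower number from compound 3 to compound 4 (0.09 log units; that floor lies within the scatter) is expected, most likely none beyond the scatter. Compound 4 is therefore estimated at 80000 nM, ranging from 20000 nM to 200000 nM.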

Compound 4, half-maximal cytotoxic concentration: 10000 nM
Compound 4: the middle estimate sits 8.0-fold (0.90 log units) above what was measured; measured number below the stated range.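

The fluorophenyl ring alone does not keep a compound at the limit on this amide-type nitrogen in this assay. The place of the fluorine counts, since 3-fluorophenyl in place of 2-fluorophenyl gives an at least 10-fold lower number from compound 1 to compound 4 (1.00 log units; beyond the scatter). Against (furan-2-yl)methyl, 3-fluorophenyl gives an at least 10-fold lower number from compound 3 to compound 4 (1.00 log units; beyond the scatter), while against 4-iodophenyl it gives a 1.1-fold higher number from compound 2 to compound 4 (0.02 log units; within the scatter), so these two aromatic rings cannot be told apart here.

From the compounds shown here alone, the full size of the two steps that start from a limit stays open because of where they begin: the limit of > 100000 nM in this assay, at which 2 of the 4 values shown sit. Going by these compounds, how an amine or a carboxylic acid on this nitrogen would behave also remains unknown.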